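The source may report more compounds than this note shows. Statements on the series, on what has been measured and on what is new or still open speak of the compounds shown alone.

Working notes on the series. Compound 1 `COc1ccc(N/C=C\C(=O)c2nc(-c3ccc(C(F)(F)F)cc3)n3ccccc23)cc1OC` was run in a functional assay on A549 cells (Homo sapiens) for cytotoxicity, read by MTT assay, with a stated time of 48 h; on this read-out lower numbers stand for stronger inhibition and higher numbers for weaker inhibition. In this assay compound 1 gives only the assay limit of > 30000 nM. Compound 2 `O=C(/C=C\Nc1ccc2cc[nH]c2c1)c1nc(-c2ccc(C(F)(F)F)cc2)n2ccccc12` carries 1H-indol-6-yl in place of 3,4-dimethoxyphenyl on the amine nitrogen. In this assay compound 2 likewise reaches only the limit of > 30000 nM. Among the compounds with values here, the one measured step is therefore unreadable: a step that the two limits leave unreadable from compound 1 to compound 2. Compound 2 thus cannot be placed relative to compound 1, since both sit at the limit of > 30000 nM in this assay, at which 2 of the 2 values shown sit.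

Compound 3 `O=C(/C=C\Nc1ccc2[nH]ccc2c1)c1nc(-c2ccc(C(F)(F)F)cc2)n2ccccc12` differs from compound 2 by 1H-indol-5-yl in place of 1H-indol-6-yl on an amine nitrogen. No measured step bears on this change, and the sole step shown is unreadable because both values sit at the limit of > 30000 nM in this assay, at which 2 of the 2 values shown sit. The step in this assay is expected to stay within the scatter, a number no higher from compound 2 to compound 3 (the limit leaves the size open). Compound 3 is estimated at 30000 nM, between 12000 nM and 100000 nM, most likely reported once more as a limit.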

Compound 3, half-maximal inhibitory concentration: 5190 nM
Beside the measured number, compound 3's estimate is 5.8-fold (0.76 log units) above it; the whole stated range lies above it.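

The amine nitrogen position proves sensitive to how the indole is attached: in this assay, with the same atoms joined differently, the change gives an at least 5.7-fold lower number from compound 2 to compound 3 (0.76 log units; beyond the scatter). Replacing 3,4-dimethoxyphenyl with 1H-indol-5-yl gives an at least 5.7-fold lower number from compound 1 to compound 3 (0.76 log units; beyond the scatter), and both sizes are only bounds, each starting from a limit. Compound 3 is the only compound shown with a number rather than a limit in this assay: the limit of > 30000 nM in this assay, at which 2 of the 3 values shown sit.

Going by these compounds, the true size of either step remains open, as does whether the number in compound 3 depends on the indole ring nitrogen and its hydrogen. 1-Methyl-1H-indol-5-yl or benzofuran-5-yl on the same amine nitrogen would address that question, and 1H-indol-4-yl would show whether the effect of the attachment point extends beyond these two indoles.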